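The source may report more compounds than this note shows. Statements on the series, on what has been measured and on what is new or still open speak of the compounds shown alone.

Compound 1 `Cc1cc(S(=O)(=O)/N=C(\N)n2nccc2-c2ccccc2)c(SCc2ccccc2)cc1Cl` gave 12000 nM.
Compound 2 `Cc1cc(S(=O)(=O)/N=C(\N)n2nccc2-c2ccccc2)c(SCc2ccc(C(F)(F)F)cc2)cc1Cl` gave 14000 nM.

In a functional assay on HCT-116 cells (Homo sapiens) for cytotoxicity, read by MTT assay, with a stated time of 72 h (a higher number here means a weaker inhibitor, a lower number a stronger inhibitor), compound 2 gives 14000 nM. Within the data shown here, compound 2 stands alongside compound 1: the two numbers lie within the scatter of each other, and the single step measured, a 1.2-fold higher number from compound 1 to compound 2 (0.07 log units; within the scatter), does not separate them.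

Compound 3 `Cc1cc(S(=O)(=O)/N=C(\N)n2nccc2-c2ccccc2)c(SCc2cccc(C(F)(F)F)c2)cc1Cl` differs from compound 2 by 3-(trifluoromethyl)phenyl in place of 4-(trifluoromethyl)phenyl on a saturated chain carbon bound to a sulfur. Among the measured compounds shown here, no measured step bears directly on this change: the one step known alters what the aromatic ring carries, not where it carries it, and it was itself within the scatter. With nothing in the two numbers pointing either way, the expectation is that compound 3 stays close to compound 2.

Compound 3 is therefore estimated at 14000 nM in this assay, with a range of 7000 nM to 28000 nM. The step this estimate implies, no change at the digits printed from compound 2 to compound 3 (within the scatter), is expected to remain within the scatter.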

Compound 3, half-maximal inhibitory concentration: 14000 nM
Compound 3: the middle estimate sits on the measured number at the digits printed, within the range that was stated.
By their numbers in this assay, from the lowest: compounds 1, 2 and 3 (each within the scatter of the next).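

In this assay, compound 2 and compound 3 cannot be told apart (no change at the digits printed from compound 2 to compound 3 (within the scatter)), so the choice of 3-(trifluoromethyl)phenyl over 4-(trifluoromethyl)phenyl on the saturated chain carbon bound to a sulfur makes no measurable difference here. The comparison with the unsubstituted compound gives the same reading (a 1.2-fold higher number from compound 1 to compound 3 (0.07 log units; within the scatter)), which means that with either placement of the trifluoromethyl group, the number stays within the scatter of compound 1. No evidence is available that could explain this result.

From the compounds shown here alone, all three compounds carry only hydrogen or trifluoromethyl on this ring, so it remains open whether an amine or a carboxylic acid there would give a number that stands apart from these. The same question stands for a longer chain in place of the benzyl group, and for changes elsewhere on the shared core.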